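Series notes: halogen exchange from compound 3 to compound 4

This account rests on a few compounds, and the source may have more. Where it says the series, first, only, none or still open, it means among the compounds named here.

Measured so far:
compound 1 `COc1ccc(/C=C/S(=O)(=O)Cc2ccc(OC)cc2)cc1` — > 20000 nM
compound 2 `COc1cc(OC)c(/C=C/S(=O)(=O)Cc2ccc(C(=O)O)cc2)c(OC)c1` — 17500 nM
compound 3 `COc1ccc(CS(=O)(=O)/C=C/c2ccc(F)cc2)cc1` — 2500 nM

In a functional assay on H157 cells (Homo sapiens) for antiproliferative activity, read by trypan blue exclusion (on this read-out lower numbers stand for stronger inhibition and higher numbers for weaker inhibition), compound 3 gives 2500 nM, the lowest of the two numbers available. The nearest neighbour is compound 2, which in this assay gives 17500 nM, a gap beyond the scatter. For compound 1 this assay reports only a limit, > 20000 nM, not a number.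

Compound 4 `COc1ccc(CS(=O)(=O)/C=C/c2ccc(Cl)cc2)cc1` is not yet measured. It differs from compound 3 by chloro in place of fluoro on an aromatic carbon.

Among the measured compounds shown here, the one measured step that touches the same position is an at least 8.0-fold lower number from compound 1 to compound 3 (0.90 log units; beyond the scatter); it compares fluoro with methoxy, not fluoro with chloro, and rests on a limit (the limit of > 20000 nM in this assay, at which 1 of the 3 values shown sits), so it bounds the size of the earlier change only from one side. For the measured compounds named here, no measured pair shows a halogen exchanged for another halogen, so the present step has no direct precedent.

The step is therefore expected to be small, with the estimate for compound 4 set close to compound 3, as a 1.4-fold lower number from compound 3 to compound 4 (0.14 log units; within the scatter). In this assay compound 4 is expected at 1800 nM, within a range from 600 nM to 5500 nM.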

Compound 4, half-maximal inhibitory concentration: 3500 nM
Compound 4: the middle estimate sits 1.9-fold (0.29 log units) below what was measured, within the range that was stated.
By their numbers in this assay, from the lowest: compounds 3 and 4 (each within the scatter of the next); then compound 2. At a limit, above all of these: compound 1.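

In this assay, this position now has its first exchange of one halogen for another: a 1.4-fold higher number from compound 3 to compound 4 (0.15 log units; within the scatter), so fluoro and chloro cannot be told apart here. Both halogens also separate from methoxy at the same place, with an at least 5.7-fold lower number from compound 1 to compound 4 (0.75 log units; beyond the scatter) standing alongside an at least 8.0-fold lower number from compound 1 to compound 3 (0.90 log units; beyond the scatter). Compound 1 is held only at a limit, so both of those steps are bounds from one side: the limit of > 20000 nM in this assay, at which 1 of the 4 values shown sits.

The compounds shown leave open what an amine or a nitrile would do in place of the halogen, and whether bromo would stay with fluoro and chloro. On these data alone, the methoxy on the other side of the sulfonyl group is the same in compound 1, compound 3 and compound 4, so its part in these numbers also remains open.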